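The source may hold more compounds than are shown below. What is called first, only, known or untested is meant among the compounds shown, and "the series" means these compounds.

In a functional assay on NCI-H460 cells (Homo sapiens) for antiproliferative activity, read by MTT assay, with a stated time of 48 h (on this read-out lower numbers stand for stronger inhibition and higher numbers for weaker inhibition), compound 1 `COc1cc(-c2cccc3nc(-c4cccc(Br)c4)oc23)cc(OC)c1OC` gives 3800 nM. Compound 2 `COc1cc(-c2cccc3nc(-c4cccc(Cl)c4)oc23)cc(OC)c1OC` gives > 25000 nM, which is a limit of the assay and not a number. Among the compounds with values here, the one measured step is an at least 6.5-fold higher number from compound 1 to compound 2 (0.81 log units; beyond the scatter), with chloro in place of bromo on an aromatic carbon. Compound 3 `COc1cc(-c2cccc3nc(-c4ccc(C)cc4)oc23)cc(OC)c1OC` differs from compound 2 by a change not yet tested in this series: 4-methylphenyl in place of 3-chlorophenyl on an aromatic carbon. In words, 4-methylphenyl stands in place of 3-chlorophenyl. Within the data shown here, no measured step makes this exchange, so the evidence is indirect: an at least 6.5-fold higher number from compound 1 to compound 2 (0.81 log units; beyond the scatter) shows only that a single change on this aromatic group can move the number beyond the scatter. A modest move to a lower number in this assay is therefore expected, though compound 3 may not reach compound 1 at 3800 nM. The estimated step is an at least 2.7-fold lower number from compound 2 to compound 3 (0.44 log units; beyond the scatter). The estimate for compound 3 is 9000 nM, with an expected range from 2500 nM to 30000 nM.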

Compound 3, half-maximal inhibitory concentration: 1900 nM
Compound 3: middle estimate off by 4.7-fold (0.68 log units), on the high side; measured number below the stated range.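

In this assay, 4-methylphenyl in place of 3-chlorophenyl gives an at least 13-fold lower number from compound 2 to compound 3 (1.11 log units; beyond the scatter), so on this aromatic carbon, next to the ring nitrogen and next to the ring oxygen, a phenyl group without a halogen can carry activity that the chloro compound does not show. The exchange of 3-bromophenyl for 4-methylphenyl gives a 2.0-fold lower number from compound 1 to compound 3 (0.30 log units; within the scatter), which lies within the scatter, so a halogen on this phenyl group is not required for a reading at this level. The reading for compound 2 is a limit of the assay and not a number, which leaves the full size of its step unknown: the limit of > 25000 nM in this assay, at which 1 of the 3 values shown sits.

The exchanges change both the substituent and its place on the phenyl group, and the compounds shown do not separate these two changes. Going by these compounds, it remains open how 3-methylphenyl, or a phenyl group bearing an amine or a carboxylic acid, would read here.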